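The compounds below may be only part of what the source reports. "The series", "measured", "known", "first", "only" and "open" are said of these compounds alone.

Compound 1 `CCN(CC)S(=O)(=O)c1ccc(S(=O)(=O)N2CCC[C@@H](C(=O)NC)C2)cc1` gives 13800 nM in a functional assay on BXPC-3 cells (Homo sapiens) for inhibition, read by MTT assay, with a stated time of 7 days; a higher number here means a weaker inhibitor, a lower number a stronger inhibitor. Compound 2 `CCN(CC)S(=O)(=O)c1ccc(S(=O)(=O)N2CCC[C@@H](C(=O)NC3CN(S(C)(=O)=O)C3)C2)cc1` gives 7400 nM in this assay, the lower of the two numbers, and the change a 1.9-fold lower number from compound 1 to compound 2 (0.27 log units; within the scatter) stays within the scatter. Compound 3 `CCN(CC)S(=O)(=O)c1ccc(S(=O)(=O)N2CCC[C@@H](c3nc(C)no3)C2)cc1` differs from compound 2 by 3-methyl-1,2,4-oxadiazol-5-yl in place of (1-(methylsulfonyl)azetidin-3-yl)carbamoyl on a saturated ring carbon. Within the data shown here, only the step from compound 1 to compound 2 is available, and it alters a substituent on the amide rather than removing the amide itself, so it bears only loosely on this change. A step of a 1.4-fold higher number from compound 2 to compound 3 (0.13 log units; within the scatter) is expected, without a clear direction. Compound 3 is therefore estimated at 10000 nM, between 3000 nM and 30000 nM.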

Compound 3, half-maximal inhibitory concentration: 2900 nM
Estimate against measurement, compound 3: 3.4-fold (0.54 log units) above; measured number below the stated range.
By their numbers in this assay, from the lowest: compound 3; then compounds 2 and 1 (each within the scatter of the next).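

Among these compounds, replacing the amide at this saturated ring carbon with 3-methyl-1,2,4-oxadiazol-5-yl gives a 2.6-fold lower number from compound 2 to compound 3 (0.41 log units; beyond the scatter) in this assay and so produces the first change here beyond the scatter. Measured against the small methylcarbamoyl group, the same ring gives a 4.8-fold lower number from compound 1 to compound 3 (0.68 log units; beyond the scatter) and points the same way, so these compounds do not need an amide at this position. Nothing available explains the drop.

Still open, going by these compounds, is whether a longer chain in place of the methyl on this ring would lower the number further. An amine or a carboxylic acid at this ring carbon also remains untested among the compounds shown.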